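This account rests on a few compounds, and the source may have more. Where it says the series, first, only, none or still open, it means among the compounds named here.

Compound 1 `Cc1ccc(SCc2ccc(C(=O)Nc3ccccc3N)cc2)cc1`: 3700 nM
Compound 2 `COc1ccc(SCc2ccc(C(=O)Nc3ccccc3N)cc2)cc1OC`: 4420 nM

Both values come from a functional assay on A-375 cells (Homo sapiens) for antiproliferative activity, read by CCK-8 assay, with a stated time of 72 h; on this read-out higher numbers stand for weaker inhibition and lower numbers for stronger inhibition. The two compounds differ only in the group on the sulfur, and their numbers lie within the usual scatter of each other, so neither can be ranked above the other. Among the compounds with values here, compound 1 therefore stands level with the only other number available.

Compound 3 `Cc1cc(C)cc(SCc2ccc(C(=O)Nc3ccccc3N)cc2)c1` keeps the core of compound 1 and changes that same group: 3,5-dimethylphenyl in place of 4-methylphenyl on a sulfur, with 3,5-dimethylphenyl in place of 4-methylphenyl on a sulfur. Within the data shown here, no measured pair shows this exact change. The closest guide is that compound 2, at 4420 nM, remains within the scatter of compound 1, at 3700 nM. No shift beyond the scatter is expected, and no firm direction. The expected size is a 1.0-fold higher number from compound 1 to compound 3 (0.01 log units; within the scatter). Compound 3 is estimated at 3800 nM, with an expected range of 1800 nM to 8000 nM.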

Compound 3, half-maximal inhibitory concentration: 3670 nM
For compound 3 the middle estimate is 1.0-fold (0.02 log units) above the measured one; low and high end bracket the measured number.
By their numbers in this assay, from the lowest: compounds 3, 1 and 2 (each within the scatter of the next).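

In this assay, 3,5-dimethylphenyl in place of 4-methylphenyl on a sulfur gives a 1.0-fold lower number from compound 1 to compound 3 (0.00 log units; within the scatter). This position therefore accepts the larger of these two carbon-only aromatic groups with no change that can be read from this measurement, so a methyl group more or less on this ring does not separate compound 3 from compound 1. No other measurement bears on this result, so it offers no explanation for why the number holds.

Still open, on these data alone, is whether an amine or a carboxylic acid on this ring would take the number beyond the scatter. It is equally unknown what a longer saturated chain would do in place of the whole aromatic group on the sulfur, or whether an oxygen could stand in for the sulfur itself.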